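The compounds below may be only part of what the source reports. "The series", "measured", "known", "first", "only" and "open" are said of these compounds alone.

Of the compounds shown here, three have so far been measured in a functional assay on CEM-DNR-bulk cells (Homo sapiens), read by MTT assay, with a stated time of 72 h; a higher number here means a weaker inhibitor, a lower number a stronger inhibitor.

Compound 1 `O=c1[nH]cnc2c1c(-c1ccoc1)cn2[C@@H]1O[C@H](CO)[C@@H](O)[C@H]1O` gives > 20000 nM, which is a limit of the assay and not a number.
Compound 2 `Cc1ncnc2c1c(I)cn2[C@@H]1O[C@H](CO)[C@@H](O)[C@H]1O` gives 12600 nM.
Compound 3 `O=c1[nH]cnc2c1c(-c1cccs1)cn2[C@@H]1O[C@H](CO)[C@@H](O)[C@H]1O` gives > 20000 nM, again a limit of the assay and not a number.

Compound 3 thus stands only at a limit on the numbers shown. The step that the two limits leave unreadable from compound 1 to compound 3 cannot be sized, since both of its ends rest at the limit of > 20000 nM in this assay, at which 2 of the 3 values shown sit. For the measured compounds named here, compound 2 alone gives a readable number, and no step connects it to compound 3.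

Compound 4 `O=c1[nH]cnc2c1c(-c1ccsc1)cn2[C@@H]1O[C@H](CO)[C@@H](O)[C@H]1O` has not yet been measured. It differs from compound 3 in one place: thiophen-3-yl in place of thiophen-2-yl on an aromatic carbon. Going by the values given here, the only measured step that bears on swapping the ring at this position is the one from compound 1 to compound 3, and its size stays unreadable because of the limit of > 20000 nM in this assay, at which 2 of the 3 values shown sit. Among the compounds with values here, no measured step therefore gives a direction or a size, and the step of a number no higher from compound 3 to compound 4 (the limit leaves the size open) is expected to be none beyond the scatter. Compound 4 is estimated to give 20000 nM in this assay, with a range from 8000 nM to 50000 nM.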

Compound 4, half-maximal inhibitory concentration: > 20000 nM
Compound 4 ended at the assay's limit; the forecaster's own chance of this, stated with the estimate: 75%; the middle value sits exactly at the limit.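

For the compounds shown here, no step among compound 1, compound 3 and compound 4 can be read, because all three rest at a limit of the assay and not at a number: the limit of > 20000 nM in this assay, at which 3 of the 4 values shown sit. The compounds shown leave open whether furan-3-yl, thiophen-2-yl and thiophen-3-yl differ at all in strength.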